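Sulfonyl amine variation and the step to the iodophenyl piperazine

The source may hold more compounds than are shown below. What is called first, only, known or untested is meant among the compounds shown, and "the series" means these compounds.

Compound 1 `CCCn1c(=O)[nH]c2nc(-c3ccc(S(=O)(=O)N(C)C)cc3)[nH]c2c1=O` carries dimethylamino on the sulfonyl sulfur; in an assay on CHO cells for displacement of a labelled ligand from adenosine receptor A3 (Homo sapiens), read by scintillation counting, with a stated time of 45 min, in the presence of a further agent that is not named here (a higher number here means a weaker inhibitor, a lower number a stronger inhibitor), compound 1 gives 1220 nM. Compound 2 `CCCn1c(=O)[nH]c2nc(-c3ccc(S(=O)(=O)N4CCN(C)CC4)cc3)[nH]c2c1=O` carries 4-methylpiperazin-1-yl there instead. In this assay compound 2 gives only a limit of the assay, > 1000 nM. Among the compounds with values here, the only measured step, a step that the limit leaves unreadable from compound 1 to compound 2, is therefore of unreadable size. Compound 3 `CCCn1c(=O)c2[nH]c(-c3ccc(S(=O)(=O)N4CCN(c5ccc(Cl)cc5)CC4)cc3)nc2n(C)c1=O` differs from compound 2 in two places. In this assay compound 3 likewise gives only a limit, > 1000 nM; see (the limit of > 1000 nM in this assay, at which 2 of the 3 values shown sit). Compound 4 `CCCn1c(=O)[nH]c2nc(-c3ccc(S(=O)(=O)N4CCN(c5ccc(I)cc5)CC4)cc3)[nH]c2c1=O` is unmeasured; its change from compound 2 is 4-iodophenyl in place of methyl on an amine nitrogen in a ring. Within the data shown here, no measured step reads this change, and compound 3, the closest analogue, stands at > 1000 nM. Compound 4 is therefore expected to give 2500 nM (range 800 nM to 8000 nM), an estimated step that the limit leaves unreadable from compound 2 to compound 4 that may again reach only a limit.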

Compound 4, inhibition constant: > 1000 nM
Compound 4: no number, only a limit; the forecaster's own chance of this, stated with the estimate: 65%; the middle value lies beyond the limit too.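

In this assay compound 4 gives only a limit, > 1000 nM. Within the data shown here, compound 2 also stands at a limit, so no step from compound 2 to compound 4 can be read. The compounds shown leave open what replacing methyl with 4-iodophenyl does to the inhibition constant.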